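Swapping the Amine on a Chain-Linked Side Group

The source may report more compounds than this note shows. Statements on the series, on what has been measured and on what is new or still open speak of the compounds shown alone.

The compounds here share one core carrying a phenyl group and two hydroxy groups, and they differ mainly in the side chain hung from a ring oxygen. Compound 2 `CCN(CC)CCCOc1cc(O)c2c(=O)cc(-c3ccccc3)oc2c1OC` carries a three-carbon chain that ends in a diethylamino group. In a functional assay on A549 cells (Homo sapiens) for cytotoxicity, read by MTT assay, with a stated time of 48 h (on this read-out lower numbers stand for stronger inhibition and higher numbers for weaker inhibition), compound 2 gives 1830 nM. Among the compounds with values here, that is the only number in the set: in this assay compound 1 `CCCCNCCCCOc1c(O)cc(O)c2c(=O)cc(-c3ccccc3)oc12` gives "not determined" (no result reported) and compound 3 `COc1c(O)cc(O)c2c(=O)cc(-c3ccc(Cl)cc3)oc12` gives "not determined" (no result reported), so compound 2 stands alone and cannot be placed above or below anything.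

Compound 4 `COc1c(OCCCCN2CCCCC2)cc(O)c2c(=O)cc(-c3ccccc3)oc12` is the untested partner of compound 2. Its difference from compound 2 is (piperidin-1-yl)methyl in place of diethylamino on a saturated chain carbon, three bonds along the chain from an oxygen on an aromatic ring. In plainer terms, the open diethylamino end of the chain is replaced by a piperidin-1-yl ring attached through one extra chain carbon, so the chain grows by one link and the nitrogen now sits inside a ring.

Within the data shown here, with no measured pair of this kind to lean on, the expectation rests only on compound 2 because compound 2 gives 1830 nM in this assay. The step of a 1.4-fold lower number from compound 2 to compound 4 (0.15 log units; within the scatter) is expected to be small, in either direction. Compound 4 is therefore expected to give 1300 nM, with a range from 400 nM to 4500 nM.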

Compound 4, half-maximal inhibitory concentration: 1150 nM
For compound 4 the middle estimate is 1.1-fold (0.05 log units) above the measured one; the range from low to high includes it.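

With compound 2 no longer alone, this position has its first comparison: in this assay the swap of 3-(diethylamino)propyl for 4-(piperidin-1-yl)butyl gives a 1.6-fold lower number from compound 2 to compound 4 (0.20 log units; within the scatter) and so leaves the two compounds indistinguishable on this read-out. At this site, on a chain attached through an oxygen on an aromatic ring, the amine end can therefore be closed into a ring and the chain lengthened by one carbon with no difference beyond the usual scatter, though this single pair speaks only for these two compounds and cannot separate the two alterations, which arrive together. Nothing in the data shown accounts for this result.

A 3-(piperidin-1-yl)propyl chain or a 4-(diethylamino)butyl chain would be needed to tell the effect of the ring from that of the added carbon, since either one would change only one of the two. From the compounds shown here alone, it also remains open whether the number stays this close with a much shorter two-carbon chain, a morpholin-4-yl ring or a primary amine at the chain end.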